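Swapping where a fused ring joins the chain

The source may hold more compounds than are shown below. What is called first, only, known or untested is meant among the compounds shown, and "the series" means these compounds.

The four compounds share an ester joined through a short chain to an oxygen that carries a fused two-ring fragment, and they fall into two pairs by core. Compound 1 `COc1ccc2c(c1)c(CC(=O)OCCOc1ccc3oc(=O)ccc3c1)c(C)n2C(=O)c1ccc(Cl)cc1` and compound 3 `COc1ccc2c(c1)c(CC(=O)OCCOc1ccc3ccc(=O)oc3c1)c(C)n2C(=O)c1ccc(Cl)cc1` are built on one core; compound 2 `CC1=C(CC(=O)OCCOc2ccc3oc(=O)ccc3c2)c2cc(F)ccc2/C1=C\c1ccc([S+](C)[O-])cc1` and the not yet measured compound 4 `CC1=C(CC(=O)OCCOc2ccc3ccc(=O)oc3c2)c2cc(F)ccc2/C1=C\c1ccc([S+](C)[O-])cc1` are built on another. The difference between the two cores is not broken down here.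

In an ADME assay on a cell-free system (plasma, Rattus norvegicus, strain Sprague-Dawley) for metabolic stability, read by LC-MS (on this read-out lower numbers stand for a shorter-lived compound and higher numbers for a longer-lived compound), compound 1 gives 0.0467 h, while compound 3 gives 0.0333 h. The change between them is a group of 11 heavy atoms (9 carbon, 2 oxygen; one six-membered aromatic ring of carbon only, one six-membered aromatic ring with 1 hetero atom) in place of a group of 11 heavy atoms (9 carbon, 2 oxygen; one six-membered aromatic ring of carbon only, one six-membered aromatic ring with 1 hetero atom), on an oxygen on a saturated carbon, and it brought a 1.4-fold lower number from compound 1 to compound 3 (0.15 log units; within the scatter). In this assay compound 2 gives 0.0917 h, a number that sits within the scatter of compound 1 but beyond the scatter of compound 3, so compound 2 can be said to outlast compound 3 but not compound 1.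

The same change, (a group of 11 heavy atoms (9 carbon, 2 oxygen; one six-membered aromatic ring of carbon only, one six-membered aromatic ring with 1 hetero atom) in place of a group of 11 heavy atoms (9 carbon, 2 oxygen; one six-membered aromatic ring of carbon only, one six-membered aromatic ring with 1 hetero atom), on an oxygen on a saturated carbon), turns compound 2 into compound 4, and it is the second occurrence of this change among these compounds. Among the compounds with values here, because its one measured example gave a 1.4-fold lower number from compound 1 to compound 3 (0.15 log units; within the scatter), a step of similar size is expected here, namely a 1.3-fold lower number from compound 2 to compound 4 (0.13 log units; within the scatter) for compound 4. Compound 4 is accordingly expected to give 0.068 h in this assay, with a likely range from 0.034 h to 0.135 h.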

Compound 4, half-life: 0.277 h
For compound 4 the middle estimate is 4.1-fold (0.61 log units) below the measured one; the measured number lies above the stated range.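

In this assay, moving the point where the fused two-ring fragment joins the chain gives a 3.0-fold higher number from compound 2 to compound 4 (0.48 log units; beyond the scatter), so on this core the change separates the two compounds by more than the usual scatter of repeated measurements. The same change on the core of compound 1 gave a step within the scatter, and the two steps do not agree, so in this series its size cannot simply be carried from one core to the other: the same change on two cores in this assay, a 1.4-fold lower number (0.15 log units; within the scatter) from compound 1 to compound 3 and a 3.0-fold higher number (0.48 log units; beyond the scatter) from compound 2 to compound 4, 4.2-fold (0.63 log units) apart, beyond the scatter of two such steps This shows that the outcome of the change depends on the core it is made on, but it does not show which part of the core is responsible or why, and one pair on each core cannot say what a further core would do.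

The compounds shown leave open how the change would behave on any third core, and whether a step of this size would persist if a longer chain stood in place of the short one. They also leave open whether an amide in place of the ester would keep the two fused-fragment attachments apart on the core of compound 2 or bring them together.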